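Cyanoguanidine series: alkyl exchange on the imine nitrogen

The compounds below may be only part of what the source reports. "The series", "measured", "known", "first", "only" and "open" are said of these compounds alone.

Measured so far:
compound 1, `CC(C)C(C)(C)/N=C(\NC#N)Nc1cccnc1`: 1 mg/kg
compound 2, `CCC(C)C(C)/N=C(\NC#N)Nc1ccncc1`: 8 mg/kg
compound 3, `CCC(/N=C(\NC#N)Nc1ccncc1)C(C)C`: 5 mg/kg

In a functional assay on the whole organism (blood, strain Wistar-Okamoto) with Rattus norvegicus as the target, with a stated time of 5 days (a lower number here means that less compound is needed, a higher number that more compound is needed for the effect), compound 3 gives 5 mg/kg, the second highest of the three numbers; compound 2 stands nearest, within the scatter, and compound 1 furthest, beyond it. Compound 4 `CC(C)C(C)(C)/N=C(\NC#N)Nc1ccncc1` is the next to be measured. The change from compound 3: 1,1,2-trimethylpropyl in place of 1-isopropylpropyl on a double-bonded nitrogen.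

For the measured compounds named here, the only measured step at this position, a 1.6-fold lower number from compound 2 to compound 3 (0.20 log units; within the scatter), lay within the scatter. Going by the values given here, compound 1 carries the same 1,1,2-trimethylpropyl group and gives 1 mg/kg, but it differs from compound 4 in the ring as well, so that pair gives no step. For compound 4 a step of a 1.3-fold lower number from compound 3 to compound 4 (0.10 log units; within the scatter) is therefore expected, within the scatter. Compound 4 is estimated at 4 mg/kg, range 1.5 mg/kg to 10 mg/kg.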

Compound 4, minimum effective dose: 20 mg/kg
Compound 4: the middle estimate sits 5.0-fold (0.70 log units) below what was measured; measured number outside the range, above it.
By their numbers in this assay, from the lowest: compound 1; then compounds 3 and 2 (each within the scatter of the next); then compound 4.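

In this assay, the alkyl group on the double-bonded nitrogen matters: 1,1,2-trimethylpropyl in place of 1-isopropylpropyl gives a step beyond the scatter (a 4.0-fold higher number from compound 3 to compound 4 (0.60 log units; beyond the scatter)), as does 1,1,2-trimethylpropyl in place of 1,2-dimethylbutyl (a 2.5-fold higher number from compound 2 to compound 4 (0.40 log units; beyond the scatter)), whereas the earlier exchange at this position stayed within it. With 1,1,2-trimethylpropyl held constant, pyridin-4-yl in place of pyridin-3-yl on an amine nitrogen gives the largest step in the set (a 20-fold higher number from compound 1 to compound 4 (1.30 log units; beyond the scatter)). No measurement shown accounts for these steps.

Open, from the compounds shown here alone, is whether the alkyl exchanges run the same way on the pyridin-3-yl compounds. Also open, going by these compounds, is how a cyclohexyl group or a longer chain on the double-bonded nitrogen would compare.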